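From compound 3 to compound 4: dropping the cyano group

The compounds below may be only part of what the source reports. "The series", "measured", "known", "first", "only" and "open" are said of these compounds alone.

Of the compounds shown here, three have so far been measured in an ADME assay on NIH3T3 cells (Mus musculus) for cytotoxicity, read by MTT assay, with a stated time of 24 h (a lower number here means a stronger inhibitor, a higher number a weaker inhibitor), and their numbers lie close together. There compound 1 `Cc1nnc(SCC(=O)N/N=c2/scc(-c3ccccc3)n2-c2ccccc2)s1` gives 197 ug/mL and compound 2 `Cn1cnnc1SCC(=O)N/N=c1/scc(-c2ccc([N+](=O)[O-])cc2)n1-c1ccccc1` gives 133 ug/mL while compound 3 `Cn1cnnc1SCC(=O)N/N=c1/scc(-c2ccc(C#N)cc2)n1-c1ccccc1` gives 153 ug/mL and so sits with the other two, within the scatter of both.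

Compound 4 `Cn1cnnc1SCC(=O)N/N=c1/scc(-c2ccccc2)n1-c1ccccc1` differs from compound 3 by a single change, hydrogen in place of cyano on an aromatic carbon, para to a large group: hydrogen in place of cyano on an aromatic carbon gives the full count.

For the measured compounds named here, the one measured step at that place is a 1.2-fold higher number from compound 2 to compound 3 (0.06 log units; within the scatter) and it swapped one group for another. Going by the values given here, no measured step shows the loss of a group there. Among the compounds with values here, with only that step to go on, no change beyond the scatter is expected in this assay for this replacement. The estimated step is a 1.0-fold higher number from compound 3 to compound 4 (0.02 log units; within the scatter) and nothing larger is expected.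

The expected value for compound 4 is 160 ug/mL with an estimated range from 90 ug/mL to 280 ug/mL in this measurement.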

Compound 4, half-maximal inhibitory concentration: 217 ug/mL
Compound 4: the middle estimate sits 1.4-fold (0.13 log units) below what was measured; measured number inside the range.
By their numbers in this assay, from the lowest: compounds 2, 3, 1 and 4 (each within the scatter of the next).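

Taking the group away altogether, rather than swapping it, still gives no change that can be told from the scatter in this assay: a 1.4-fold higher number from compound 3 to compound 4 (0.15 log units; within the scatter) and a 1.6-fold higher number from compound 2 to compound 4 (0.21 log units; within the scatter), so at this place on the six-membered aromatic ring, para to a large group, neither cyano nor nitro is set apart from plain hydrogen. With the phenyl compounds, the exchange of 5-methyl-1,3,4-thiadiazol-2-yl for 4-methyl-4H-1,2,4-triazol-3-yl on the sulfur can now be read directly, and it too stays within the scatter: a 1.1-fold higher number from compound 1 to compound 4 (0.04 log units; within the scatter). No supporting measurement bears on why these numbers stay together.

The compounds shown leave open whether an amine or a carboxylic acid at this place would move the number beyond the scatter. They also leave open whether any change elsewhere on the shared core would do so.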